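The source may hold more compounds than are shown below. What is called first, only, known or untested is meant among the compounds shown, and "the series" means these compounds.

Compound 1 `Cc1ccc(S(=O)(=O)N2CC(c3nc(-c4cccc(Cl)c4)no3)C2)cc1` gives > 10000 nM in an assay on HEK293 cells for positive allosteric modulation of metabotropic glutamate receptor 5 (Homo sapiens), read by FLIPR; on this read-out higher numbers stand for an effect only at larger amounts of compound and lower numbers for an effect already at smaller amounts.
Compound 2 `O=S(=O)(c1ccc(F)cc1)N1CC(c2nc(-c3cccc(Cl)c3)no2)C1` gives > 10000 nM in this assay.

For compound 2 this value is a limit of the assay, not a number. The step from compound 1 to compound 2 a step that the two limits leave unreadable from compound 1 to compound 2 therefore cannot be read, and the limit of > 10000 nM in this assay, at which 2 of the 2 values shown sit, shows that both measured values sit at that limit. Compound 3 `Cc1cccc(-c2noc(C3CN(S(=O)(=O)c4ccc(F)cc4)C3)n2)c1` differs from compound 2 by methyl in place of chloro on an aromatic carbon. Within the data shown here, no measured step bears on this change, so nothing beyond the scatter is expected in this assay. Compound 3 is expected to stay near the limit, at about 15000 nM, within 5000 nM to 50000 nM. This means an expected step that the limit leaves unreadable from compound 2 to compound 3.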

Compound 3, half-maximal effective concentration: > 10000 nM
Compound 3: only a limit was reported (the forecaster's own chance of this, stated with the estimate: 80%); the middle value does not contradict the limit.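

Compound 2 and compound 3 both give only a limit of the assay, and the step between them cannot be read. The compounds shown leave open whether 3-chlorophenyl and 3-methylphenyl differ at all in this assay.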